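The source may hold more compounds than are shown below. What is called first, only, known or untested is meant among the compounds shown, and "the series" means these compounds.

For the measured compounds named here, compound 1 `CN1CCN(CC(=O)O[C@@H]2C[C@@H]3CC[C@@]2(C)C3(C)C)CC1` is the more tolerated of the two compounds measured so far in an ADME assay on HEK-293T cells (Homo sapiens) for cytotoxicity, read by MTT assay, with a stated time of 48 h (a lower number here means that less compound is tolerated, a higher number that more compound is tolerated), where compound 1 gives 313000 nM. Its nearest neighbour is compound 2 `CCN1CCN(CC(=O)O[C@@H]2C[C@@H]3CC[C@@]2(C)C3(C)C)CC1`, which in this assay gives 130000 nM; the step of a 2.4-fold lower number from compound 1 to compound 2 (0.38 log units; beyond the scatter) shows that adding a single carbon to the amine nitrogen of the ring brought a modestly lower tolerated concentration. Compound 3 `CCN(CC)CCC(=O)O[C@@H]1C[C@@H]2CC[C@@]1(C)C2(C)C` has not yet been measured. Relative to compound 1 it carries a different change: (diethylamino)methyl in place of 4-methylpiperazin-1-yl on a saturated chain carbon bound to a carbonyl carbon. Going by the values given here, the only measured step that bears on it is the one from compound 1 to compound 2, which also enlarged the amine end of the ester side chain and lowered the number modestly, so a step of similar size and direction is expected here, a 2.1-fold lower number from compound 1 to compound 3 (0.32 log units; beyond the scatter). Compound 3 is therefore estimated to give 150000 nM in this assay, with a plausible range from 60000 nM to 400000 nM.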

Compound 3, half-maximal cytotoxic concentration: 327000 nM
The estimate for compound 3 lay 2.2-fold (0.34 log units) below the measured number; measured number inside the range.
By their numbers in this assay, from the lowest: compound 2; then compounds 1 and 3 (each within the scatter of the next).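

In this assay, swapping the 4-methylpiperazin-1-yl ring for the open-chain (diethylamino)methyl group gives a 1.0-fold higher number from compound 1 to compound 3 (0.02 log units; within the scatter), so the open-chain group and the ring read alike here. The earlier step, a 2.4-fold lower number from compound 1 to compound 2 (0.38 log units; beyond the scatter), came from a small edit to the ring, whereas here the whole ring is replaced and the change stays within the scatter, so among these compounds a larger change to the side chain did not bring a larger shift. Nothing available explains why these two groups give such similar numbers.

Going by these compounds, it remains open whether other amines at this place, such as morpholine or piperidine, would also match compound 1. A longer chain between the carbonyl and the amine, or an amide in place of the ester, is equally untested in what is shown here.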